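Shortening the Ring Substituent from Benzyl to Methyl

The compounds below may be only part of what the source reports. "The series", "measured", "known", "first", "only" and "open" are said of these compounds alone.

Among the measured compounds shown here, in a functional assay on aorta (Rattus norvegicus) (a lower number here means a stronger inhibitor, a higher number a weaker inhibitor), compound 2 `O=c1ccc(CCCOCc2ccccc2)nn1Cc1ccccc1` gives 32500 nM, the only actual number among the two values recorded. For compound 1 `Cn1nc(COCc2ccccc2)ccc1=O` the result is a limit rather than a number: > 100000 nM, that is the limit of > 100000 nM in this assay, at which 1 of the 2 values shown sits. Compound 3 `Cn1nc(CCCOCc2ccccc2)ccc1=O` has not yet been measured in this assay. It differs from compound 2 by hydrogen in place of phenyl on a saturated chain carbon bound to an aromatic nitrogen, in words hydrogen in place of phenyl on a saturated chain carbon bound to an aromatic nitrogen. For the measured compounds named here, no measured pair shows this change, so the step of a 3.1-fold higher number from compound 2 to compound 3 (0.49 log units; beyond the scatter) is an expectation of weaker inhibition. Compound 3 is estimated at 100000 nM, between 30000 nM and 300000 nM.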

Compound 3, half-maximal inhibitory concentration: 76400 nM
Compound 3: the middle estimate sits 1.3-fold (0.12 log units) above what was measured; the range from low to high includes it.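

This pair gives the first measured view of this position. In this assay, the change from benzyl to methyl gives a 2.4-fold higher number from compound 2 to compound 3 (0.37 log units; beyond the scatter), so losing the phenyl costs a modest amount of inhibition but does not remove it, and both compounds remain weak inhibitors. Nothing shown here explains why the step has this size.

Still open, from the compounds shown here alone, is how an ethyl group or a longer chain ending in an amine would behave at this place, and so whether the step follows group size or depends on the phenyl ring itself.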